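The source may report more compounds than this note shows. Statements on the series, on what has been measured and on what is new or still open speak of the compounds shown alone.

The series was examined in an assay on membranes from brain for binding affinity to Monoglyceride lipase (Mus musculus), read by fluorescence, with stated times of 1 h and 30 min; on this read-out lower numbers stand for stronger inhibition and higher numbers for weaker inhibition. Compound 1, `O=C(N1CCCN(Cc2ccc(OCc3ccccc3)cc2)CC1)n1cccn1`, gives 10000 nM in this assay. Compound 2, `N#Cc1cnn(C(=O)N2CCCN(Cc3ccc(OCc4ccccc4)cc3)CC2)c1`, carries the change cyano in place of hydrogen on an aromatic carbon relative to compound 1. In this assay compound 2 gives 10000 nM; the resulting step is no change at the digits printed from compound 1 to compound 2 (within the scatter). Compound 3, `CN(CCN(C)C(=O)n1cccn1)Cc1ccc(OCc2ccccc2)cc1`, is built on a different core, and the difference between its core and the core of compound 1 is not broken down here. In this assay compound 3 gives 660 nM, the lowest of the three values, with compound 1 and compound 2 both standing beyond the scatter above it.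

Compound 4, `CN(CCN(C)C(=O)n1cc(C#N)cn1)Cc1ccc(OCc2ccccc2)cc1`, has not yet been measured. It differs from compound 3 by cyano in place of hydrogen on an aromatic carbon, which is the same change as that separating compound 2 from compound 1. Among the measured compounds shown here, the only precedent for this change within the set is the pair of compound 1 and compound 2, where the value did not move within the scatter. On that ground compound 4 is expected to show a step of a 1.1-fold lower number from compound 3 to compound 4 (0.04 log units; within the scatter). The estimate for compound 4 in this assay is 600 nM, expected to fall between 200 nM and 2000 nM. That estimate rests on a single pair measured on a different core, so the range is kept wide.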

Compound 4, half-maximal inhibitory concentration: 260 nM
Compound 4: middle estimate off by 2.3-fold (0.36 log units), on the high side, within the range that was stated.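

In this assay, the change from 1H-pyrazol-1-yl to 4-cyano-1H-pyrazol-1-yl gives a 2.5-fold lower number from compound 3 to compound 4 (0.40 log units; beyond the scatter), a modest step. Set beside the earlier step on the core of compound 1, the result gives no evidence that the core alters what this change does, since the two steps cannot be told apart: the same change on two cores in this assay, no change at the digits printed (within the scatter) from compound 1 to compound 2 and a 2.5-fold lower number (0.40 log units; beyond the scatter) from compound 3 to compound 4, 2.5-fold (0.40 log units) apart, within the scatter of two such steps This shows only that the two pairs are compatible with the change carrying from one core to the other; it does not show that the step is truly the same on both, and two pairs say nothing about any further core.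

The compounds shown leave open whether a chlorine atom, a carboxylic acid or an amine on the same aromatic carbon would give steps that agree across the two cores as closely as those for cyano do. Among the compounds shown here, also open is whether a longer chain in place of the one in compound 3 would keep the value of that core, and whether cyano would then give a step of similar size.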